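Amine-bearing acyl groups on the shared core: compound 3 to compound 4

The source may report more compounds than this note shows. Statements on the series, on what has been measured and on what is new or still open speak of the compounds shown alone.

In a functional assay on PANC-1 cells (Homo sapiens) for inhibition, read by XTT assay, with a stated time of 72 h (on this read-out lower numbers stand for stronger inhibition and higher numbers for weaker inhibition), the series reads as follows:
- compound 1 `CCCCCCCC/C=C\CCCCCCCCOC[C@@H]1CCCN1C(=O)OC(C)(C)C` gives 80000 nM
- compound 2 `CCCCCCCC/C=C\CCCCCCCCOC[C@@H]1CCCN1C(=O)[C@@H]1CCCN1C(=O)OC(C)(C)C` gives > 100000 nM as a limit of the assay, not a number
- compound 3 `CCCCCCCC/C=C\CCCCCCCCOC[C@@H]1CCCN1C(=O)[C@@H]1CCCN1` gives 5000 nM

Compound 3 stands lowest on these values, and both of its steps from the other compounds lie beyond the scatter. Compound 4 `CCCCCCCC/C=C\CCCCCCCCOC[C@@H]1CCCN1C(=O)CN` carries aminomethyl in place of pyrrolidin-2-yl on a carbonyl carbon.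

Among the measured compounds shown here, two measured steps bear on this change. Pyrrolidin-2-yl in place of tert-butoxy gave a large step (a 16-fold lower number from compound 1 to compound 3 (1.20 log units; beyond the scatter)). Removing tert-butoxycarbonyl from the amine nitrogen in a ring also gave a large step (an at least 20-fold lower number from compound 2 to compound 3 (1.30 log units; beyond the scatter)). With that nitrogen still capped, the floor of the step (an at least 1.2-fold higher number from compound 1 to compound 2 (0.09 log units; that floor lies within the scatter)) lies within the scatter. Among these three compounds, the low number appears only with the uncapped amine, which compound 4 also has. For the measured compounds named here, no measured step alters the pyrrolidin-2-yl group itself, so the estimate is loose. In this assay, going by the values given here, no step clearly beyond the scatter is expected, with a slight lean towards a higher number.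

The expected step is one (a 1.6-fold higher number from compound 3 to compound 4 (0.20 log units; within the scatter)) of modest size. For compound 4 the estimated value is 8000 nM within an expected range of 2500 nM to 25000 nM for now.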

Compound 4, half-maximal inhibitory concentration: 7700 nM
Estimate against measurement, compound 4: 1.0-fold (0.02 log units) above; measured number inside the range.
By their numbers in this assay, from the lowest: compounds 3 and 4 (each within the scatter of the next); then compound 1. At a limit, above all of these: compound 2.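

In this assay, the pyrrolidin-2-yl ring and its defined stereocentre can give way to aminomethyl on this carbonyl carbon without a step beyond the scatter: a 1.5-fold higher number from compound 3 to compound 4 (0.19 log units; within the scatter). Among the compounds shown here, the large step away from the tert-butoxy carbamate therefore no longer rests on compound 3 alone, as a second uncapped amine gives a 10-fold lower number from compound 1 to compound 4 (1.02 log units; beyond the scatter), and among the four compounds the low numbers belong only to compound 3 and compound 4, with no compound going against this. Compound 2 gives a limit of the assay, not a number, so an at least 12-fold lower number from compound 2 to compound 4 (1.11 log units; beyond the scatter) is only a floor: the limit of > 100000 nM in this assay, at which 1 of the 4 values shown sits.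

As far as these compounds go, whether the low numbers follow the amine itself remains open, and a hydroxyl or a methyl in place of the amine of the aminomethyl group, or a longer aminoalkyl chain on the same carbonyl carbon, would separate the amine from the rest of the acyl group. Also open, from the compounds shown here alone, is how far these numbers depend on the shared core, for instance on the long ether chain, which is the same in all four compounds.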